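Ring Nitrogen Aryl Exchange Leading to Compound 4

The compounds below may be only part of what the source reports. "The series", "measured", "known", "first", "only" and "open" are said of these compounds alone.

Three members of the series share one core and differ only in the group on an amine nitrogen in a ring. Compound 1 `Nc1scc(CN2CCN(c3cccc(Cl)c3Cl)CC2)c1C(=O)c1ccc(Cl)cc1` gives 2% in an assay on CHO cells for displacement of a labelled ligand from adenosine receptor A1 (Homo sapiens), read by scintillation counting, with a stated time of 120 min, tested at 10 uM (on this read-out higher numbers stand for more inhibition at the one concentration tested (going by the name of the read-out) and lower numbers for less inhibition), compound 2 `Nc1scc(CN2CCN(C3CCCCCC3)CC2)c1C(=O)c1ccc(Cl)cc1` gives 0%, and compound 3 `Nc1scc(CN2CCN(c3ccc(F)cc3F)CC2)c1C(=O)c1ccc(Cl)cc1` gives 1%. Compound 3 sits within the scatter of both neighbours: the step of a number 1 percentage points lower from compound 1 to compound 3 (within the scatter) and the step of a number 1 percentage points higher from compound 2 to compound 3 (within the scatter) are both small, so the three values form one flat cluster with no real separation.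

Compound 4 `Nc1scc(CN2CCN(c3ccccc3Cl)CC2)c1C(=O)c1ccc(Cl)cc1` carries the change (2-chlorophenyl in place of 2,4-difluorophenyl on an amine nitrogen in a ring). Among the measured compounds shown here, the steps that bear on it are those at the same ring nitrogen, a number 1 percentage points lower from compound 1 to compound 3 (within the scatter) and a number 1 percentage points higher from compound 2 to compound 3 (within the scatter), neither of which moved the read-out beyond the scatter despite exchanging a cycloheptyl for an aryl group or one halogenated phenyl for another. No exchange at this position has yet produced a measurable effect, so the expectation is a step of no change at the digits printed from compound 3 to compound 4 (within the scatter) that stays within the scatter. Compound 4 is therefore estimated at 1%, expected to fall between -5% and 8%.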

Compound 4, a percentage reported as inhibition, at one concentration (the size of the read-out at that concentration, not a potency): 2%
Compound 4: middle estimate off by 1 percentage points, on the low side, and the stated range covers the measured number.
By their numbers in this assay, from the lowest: compounds 2, 3, 1 and 4 (each within the scatter of the next).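

In this assay the exchange at the ring nitrogen leaves a number 1 percentage points higher from compound 3 to compound 4 (within the scatter) and, against the saturated group, a number 2 percentage points higher from compound 2 to compound 4 (within the scatter), so a 2-chlorophenyl group does not separate from either 2,4-difluorophenyl or cycloheptyl. New here is a change within one aryl group, hydrogen in place of chloro on an aromatic carbon, which gives no change at the digits printed from compound 1 to compound 4 (within the scatter); on these four compounds, removing that chloro has no readable effect. No supporting data explain this flat response.

Still open, from the compounds shown here alone, is whether any group on this nitrogen can lift the read-out beyond the scatter, for example a benzyl group or a pyridine ring. Going by these compounds, all four compounds also keep the same remainder of the core, so the effect of an amide in place of the free amine remains unknown.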